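A Methyl Group Added to a Weakly Active Scaffold

The source may report more compounds than this note shows. Statements on the series, on what has been measured and on what is new or still open speak of the compounds shown alone.

Compound 1, `Cc1ccc2nc(Nc3nc(Nc4ccc(S(C)(=O)=O)cc4)ncc3F)sc2c1`: > 50000 nM
Compound 2, `CS(=O)(=O)c1ccc(Nc2nccc(Nc3nc4ccc(F)cc4s3)n2)cc1`: > 60000 nM
Compound 3, `CS(=O)(=O)c1ccc(Nc2nccc(Nc3nc4ccccc4s3)n2)cc1`: 10600 nM

All three compounds were tested in a functional assay on MCF7 cells (Homo sapiens) for antiproliferative activity, read by MTT assay, with a stated time of 48 h; a lower number here means a stronger inhibitor, a higher number a weaker inhibitor. Compound 1 reached only the limit > 50000 nM, not a number. Compound 2 likewise reached only the limit > 60000 nM. Within the data shown here, compound 3 is the one compound with a measured number, 10600 nM, so it stands as the single fixed point among the three. Among the measured compounds shown here, the one step that can be sized is an at least 5.6-fold lower number from compound 2 to compound 3 (0.75 log units; beyond the scatter), where a hydrogen replaces a fluoro on an aromatic carbon, read against (the limit of > 60000 nM in this assay, at which 1 of the 3 values shown sits).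

Compound 4, `Cc1ccc2nc(Nc3ccnc(Nc4ccc(S(C)(=O)=O)cc4)n3)sc2c1`, differs from compound 3 by methyl in place of hydrogen on an aromatic carbon. For the measured compounds named here, no measured step covers a methyl added on its own. Compound 1 carries the same methyl together with a fluoro on another ring, and it too gave only a limit. The sized step from compound 2 to compound 3 shows that a substituent on this ring went with a weaker result, so adding one is expected to shift the number upward, if it shifts at all. For compound 4 the estimate in this assay is 20000 nM, with a range from 6000 nM to 60000 nM, which means an expected step of a 1.9-fold higher number from compound 3 to compound 4 (0.28 log units; within the scatter).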

Compound 4, half-maximal inhibitory concentration: > 50000 nM
Compound 4 ended at the assay's limit; the forecaster's own chance of this, stated with the estimate: 35%; at least 2.5-fold (0.39 log units) between middle value and limit.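

Among these compounds, this result gives the first sized step for a methyl on its own. In this assay, methyl in place of hydrogen on this aromatic carbon of the fused two-ring system gives an at least 4.7-fold higher number from compound 3 to compound 4 (0.67 log units; beyond the scatter), a change beyond the scatter. Compound 2 carries a fluoro on the same carbon, and the step of an at least 5.6-fold lower number from compound 2 to compound 3 (0.75 log units; beyond the scatter) already pointed the same way, so among these compounds only compound 3, with hydrogen there, gives a measured number, while compound 1, compound 2 and compound 4, each with a substituent on that carbon, end at limits. The steps from compound 2 to compound 4 and from compound 1 to compound 4 cannot be read, because each pair ends in two limits: the limit of > 50000 nM in this assay, at which 2 of the 4 values shown sit.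

On these data alone, how far past its limit compound 4 lies stays open, so the full size of the methyl step remains unknown. As far as these compounds go, it also stays open whether an amine or a carboxylic acid on this same aromatic carbon would give a measurable number, as hydrogen does in compound 3.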